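This account rests on a few compounds, and the source may have more. Where it says the series, first, only, none or still open, it means among the compounds named here.

Compound 1 `Cc1cc(C)c(NC(=O)N(Cc2cccc(-c3ccn(C)n3)c2)C2CCCCCC2)c(C)c1` gives < 1 mg/kg in a functional assay on a cell-free system (plasma) with sterol O-acyltransferase, Soat (Rattus norvegicus) as the target; on this read-out higher numbers stand for an effect only at larger amounts of compound and lower numbers for an effect already at smaller amounts; this is a limit of the assay, not a number.
Compound 2 `Cc1cc(C)c(NC(=O)N(Cc2cccc(-c3cnn(C)c3)c2)C2CCCCCC2)c(C)c1` gives < 1 mg/kg in this assay; this too is a limit of the assay.

Compound 2 therefore stands at a limit, and nothing more than that is known of its place. Going by the values given here, the only measured step, a step that the two limits leave unreadable from compound 1 to compound 2, cannot be read, since both ends are limits; what is known is summed up by the limit of < 1 mg/kg in this assay, at which 2 of the 2 values shown sit, so no size can be attached to swapping one methylpyrazolyl for the other.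

Compound 3 `Cc1cc(C)c(NC(=O)N(Cc2cccc(-c3c[nH]cn3)c2)C2CCCCCC2)c(C)c1` differs from compound 2 by 1H-imidazol-4-yl in place of 1-methyl-1H-pyrazol-4-yl on an aromatic carbon. Among the compounds with values here, no measured step touches this change, and the single step that exists is unreadable, so there is nothing to suggest a shift beyond the scatter in either direction. The step from compound 2 to compound 3 in this assay is estimated as a step that the limit leaves unreadable from compound 2 to compound 3, which is to say none that can be told apart from repetition. Compound 3 is accordingly expected to give 0.7 mg/kg in this assay, within a range of 0.2 mg/kg to 2.5 mg/kg, and most likely the assay will again report only the limit.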

Compound 3, dose for half-maximal effect: < 1 mg/kg
Compound 3: only a limit was reported (the forecaster's own chance of this, stated with the estimate: 70%); the middle value is on the limit's open side.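

Compound 3 also gives only a limit of the assay, so its steps from compound 1 and from compound 2 cannot be read, and the three compounds cannot be ranked: the limit of < 1 mg/kg in this assay, at which 3 of the 3 values shown sit. The compounds shown leave open how far apart compound 1, compound 2 and compound 3 lie in this assay, and whether exchanging these five-membered rings changes the dose at all.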